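The source may hold more compounds than are shown below. What is called first, only, known or untested is meant among the compounds shown, and "the series" means these compounds.

Measured so far in the series, all in a physicochemical assay for solubility, at pH 7.4; on this read-out lower numbers stand for lower solubility and higher numbers for higher solubility:
- compound 1 (`Cc1cc(NC(=O)Nc2cccc(C(N)=O)c2)c2ccccc2n1`) gives 100 nM
- compound 2 (`COC(=O)c1ccc(NC(=O)Nc2cc(C)nc3ccccc23)cc1`) gives 1200 nM
- compound 3 (`Cc1cc(NC(=O)Nc2cc(Cl)cc(Cl)c2)c2ccccc2n1`) gives 800 nM

Compound 1 holds the lowest number of the three, and both other compounds lie above it by more than the scatter. The next compound to be read is compound 4 (`Cc1cc(NC(=O)Nc2cccc(C(F)(F)F)c2)c2ccccc2n1`). It is compound 1 with trifluoromethyl in place of carbamoyl on an aromatic carbon, and the change sits on a six-membered aromatic ring of carbon only, meta to a large group.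

Among the measured compounds shown here, no two measured compounds differ in one place, so the series offers no direct step for this change and any forecast is loose. For the measured compounds named here, the only guide is that compound 1 gives 100 nM, while compound 3 (800 nM) and compound 2 (1200 nM), neither of which carries carbamoyl, both read higher. On that thin basis, a rise beyond the scatter is expected in this assay, with an estimated step (a 5.0-fold higher number from compound 1 to compound 4 (0.70 log units; beyond the scatter)) that stops short of the top of the series. For compound 4 the estimated value is 500 nM, with an expected range (150 nM to 1600 nM).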

Compound 4, solubility: 100 nM
The estimate for compound 4 lay 5.0-fold (0.70 log units) above the measured number; the measured number lies below the stated range.
By their numbers in this assay, from the lowest: compounds 1 and 4 (each within the scatter of the next); then compounds 3 and 2 (each within the scatter of the next).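

In this assay, the series now has its first direct step, no change at the digits printed from compound 1 to compound 4 (within the scatter): on this six-membered aromatic ring of carbon only, meta to a large group, trifluoromethyl in place of carbamoyl leaves the read-out within the scatter. The change removes the hydrogen-bond donor, the hydrogen-bond acceptor and the double bond outside aromatic rings that carbamoyl carries, and so, on the core of compound 1, this exchange alone does not separate the two compounds in this read-out. Nothing available bears on why these two groups read alike.

On these data alone, whether any substituent at this position can move the number beyond the scatter remains open, since an amine, a carboxylic acid or a longer chain such as propyl could each read differently from carbamoyl and trifluoromethyl. Also open, as far as these compounds go, is whether the same exchange would stay within the scatter at another place on this ring or on a different core, as this single pair speaks only for its own position.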